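The source may report more compounds than this note shows. Statements on the series, on what has been measured and on what is new or still open speak of the compounds shown alone.

Measured compounds:
compound 1, `Cc1ccc(S(=O)(=O)c2nc3ccccc3nc2Nc2cccc(O)c2)cc1`, 400 nM
compound 2, `Cc1ccc(S(=O)(=O)c2nc3ccccc3nc2Nc2ccc(F)cc2)cc1`, 5100 nM
compound 3, `O=S(=O)(c1ccc(Br)cc1)c1nc2ccccc2nc1Nc1cccc(O)c1`, 200 nM

In a functional assay on HL-60 cells (Homo sapiens) for cytotoxicity, read by MTT assay, with a stated time of 72 h (on this read-out higher numbers stand for weaker inhibition and lower numbers for stronger inhibition), compound 1 gives 400 nM. Compound 2 differs from compound 1 by 4-fluorophenyl in place of 3-hydroxyphenyl on a nitrogen on an aromatic ring, and in this assay compound 2 gives 5100 nM, a step of a 13-fold higher number from compound 1 to compound 2 (1.11 log units; beyond the scatter). Compound 3 differs from compound 1 by bromo in place of methyl on an aromatic carbon; in this assay compound 3 gives 200 nM, a step of a 2.0-fold lower number from compound 1 to compound 3 (0.30 log units; within the scatter), so the values of compound 1 and compound 3 cannot be told apart.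

Compound 4, `O=S(=O)(c1ccc(Br)cc1)c1nc2ccccc2nc1Nc1ccc(F)cc1`, has not been measured. It differs from compound 3 by 4-fluorophenyl in place of 3-hydroxyphenyl on a nitrogen on an aromatic ring. This is the same change that separates compound 2 from compound 1, and the place lines of the two changes read the same word for word, so it is the same change made on the core of compound 3 rather than on the core of compound 1. The two cores differ by bromo in place of methyl on an aromatic carbon, a difference whose step is within the scatter.

Among the compounds with values here, with only one earlier instance to go on, the expectation for compound 4 rests on that step: because a 13-fold higher number from compound 1 to compound 2 (1.11 log units; beyond the scatter) was large, the step from compound 3 to compound 4 is expected to be of similar size, a 13-fold higher number from compound 3 to compound 4 (1.11 log units; beyond the scatter). Compound 4 is therefore estimated at 2600 nM in this assay, with a range from 1000 nM to 7000 nM.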

Compound 4, half-maximal inhibitory concentration: 260 nM
The estimate for compound 4 lay 10-fold (1.00 log units) above the measured number; measured number outside the range, below it.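

In this assay, 4-fluorophenyl in place of 3-hydroxyphenyl on the core of compound 3 gave a step of a 1.3-fold higher number from compound 3 to compound 4 (0.11 log units; within the scatter), so the large step seen on the core of compound 1 did not carry over to this core: the same change on two cores in this assay, a 13-fold higher number (1.11 log units; beyond the scatter) from compound 1 to compound 2 and a 1.3-fold higher number (0.11 log units; within the scatter) from compound 3 to compound 4, 9.8-fold (0.99 log units) apart, beyond the scatter of two such steps. Read the other way, bromo in place of methyl on an aromatic carbon gave a step of a 20-fold lower number from compound 2 to compound 4 (1.29 log units; beyond the scatter) in the 4-fluorophenyl pair, although the same change stayed within the scatter in the 3-hydroxyphenyl pair: the same change on two cores in this assay, a 2.0-fold lower number (0.30 log units; within the scatter) from compound 1 to compound 3 and a 20-fold lower number (1.29 log units; beyond the scatter) from compound 2 to compound 4, 9.8-fold (0.99 log units) apart, beyond the scatter of two such steps. The two changes therefore do not add up independently here, and the size of a step on one core did not predict its size on the other, but these four compounds form a single comparison and show neither why the steps differ nor whether the same would hold for other groups.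

The compounds shown leave open whether chloro or methoxy in place of bromo would give the same large step in the 4-fluorophenyl pair. They also leave open how an unsubstituted phenyl on the nitrogen would behave on either core, which would show whether 3-hydroxyphenyl or 4-fluorophenyl accounts for the gap between the two steps.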